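A few compounds are considered here, and "the series" means these few. Any claim that something is new, unique, unknown or untested is made for them only; others in the source may bear on it.

In a functional assay on HL-60 cells (Homo sapiens) for cytotoxicity, read by CellTiter-Blue, with a stated time of 48 h (on this read-out lower numbers stand for stronger inhibition and higher numbers for weaker inhibition), compound 3 `CCOC(=O)CC1C(C(=O)OCC)=C(N)Oc2ccc(-c3cc(F)cc(F)c3)cc21` gives 35900 nM and holds the higher of the two actual numbers. Compound 1 `C#CCOC(=O)CC1C(C(=O)OCC)=C(N)Oc2ccc(-c3cc(OC)cc(OC)c3)cc21` gives 4700 nM and lies clearly lower. Compound 2 `COc1cc(OC)cc(-c2ccc3c(c2)C(CC(=O)OCC2CO2)C(C(=O)OCC2CO2)=C(N)O3)c1` gives > 80000 nM as a limit of the assay and not a number. Compound 4 `CCOC(=O)CC1C(C(=O)OCC)=C(N)Oc2ccc(-c3ccnc(OC)c3)cc21` is still unmeasured. It carries 2-methoxypyridin-4-yl in place of 3,5-difluorophenyl on an aromatic carbon and is otherwise unchanged. Among the measured compounds shown here, no measured pair shows this swap alone. Compound 1 also carries methoxy groups and gives 4700 nM while differing elsewhere too. A moderate move toward stronger inhibition is therefore expected (a 2.0-fold lower number from compound 3 to compound 4 (0.30 log units; within the scatter)). Compound 4 is estimated at 18000 nM with an expected range (5000 nM to 60000 nM).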

Compound 4, half-maximal inhibitory concentration: 10200 nM
Beside the measured number, compound 4's estimate is 1.8-fold (0.25 log units) above it; the range from low to high includes it.
By their numbers in this assay, from the lowest: compound 1; then compound 4; then compound 3. At a limit, above all of these: compound 2.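

With 2-methoxypyridin-4-yl in place of 3,5-difluorophenyl on this aromatic carbon, this assay gives a 3.5-fold lower number from compound 3 to compound 4 (0.55 log units; beyond the scatter) and so shows, in a change at one place alone, that the group here affects the read-out. The two groups have the same number of heavy atoms, but only the entering one has a ring nitrogen, a methoxy group and hydrogen-bond acceptors. Nothing measured here shows which of these differences accounts for the step. Going by these compounds, whether an amine or a carboxylic acid on this ring would lower the number further remains open, as does the effect of an unsubstituted phenyl at this position.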